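The source may report more compounds than this note shows. Statements on the series, on what has been measured and on what is new or still open speak of the compounds shown alone.

Compound 1 `C/C(=C(/c1ccc(/C=C/C(=O)O)cc1)c1ccc2[nH]ncc2c1)c1ccccc1` carries a methyl on a double-bonded chain carbon bound to an aromatic carbon and a double-bonded chain carbon. In a functional assay on MCF7 cells (Homo sapiens) for cytotoxicity, read by CellTiter-Glo, with a stated time of 5 days (on this read-out higher numbers stand for weaker inhibition and lower numbers for stronger inhibition), compound 1 gives 40 nM, the second highest of the three numbers measured. Compound 2 `COCC/C(=C(/c1ccc(/C=C/C(=O)O)cc1)c1ccc2[nH]ncc2c1)c1ccccc1` gives 63 nM, and a 1.6-fold higher number from compound 1 to compound 2 (0.20 log units; within the scatter). Compound 3 `O=C(O)/C=C/c1ccc(/C(=C(\c2ccccc2)C(F)F)c2ccc3[nH]ncc3c2)cc1` gives 14 nM; here a 2.9-fold lower number from compound 1 to compound 3 (0.46 log units; beyond the scatter), and a 4.5-fold lower number from compound 2 to compound 3 (0.65 log units; beyond the scatter). Compound 4 `O=C(O)/C=C/c1ccc(/C(=C(\c2ccccc2)C2CCCC2)c2ccc3[nH]ncc3c2)cc1` differs from compound 1 by cyclopentyl in place of methyl on a double-bonded chain carbon bound to an aromatic carbon and a double-bonded chain carbon. The steps to compound 3 show that replacing the methyl at this place can move the number beyond the scatter, but cyclopentyl is a different group from difluoromethyl, so no step beyond the scatter is expected: a 1.1-fold higher number from compound 1 to compound 4 (0.05 log units; within the scatter). Compound 4 is therefore estimated at 45 nM, between 15 nM and 130 nM.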

Compound 4, half-maximal inhibitory concentration: 10 nM
For compound 4 the middle estimate is 4.5-fold (0.65 log units) above the measured one, and the stated range ends above it.
By their numbers in this assay, from the lowest: compounds 4 and 3 (each within the scatter of the next); then compounds 1 and 2 (each within the scatter of the next).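

In this assay, a ring at this place on the double-bonded chain carbon goes with a lower number: cyclopentyl, with its five carbon atoms, gives a 4.0-fold lower number from compound 1 to compound 4 (0.60 log units; beyond the scatter) and a 6.3-fold lower number from compound 2 to compound 4 (0.80 log units; beyond the scatter) when it replaces the smaller methyl and the open-chain 2-methoxyethyl. Against difluoromethyl it gives a 1.4-fold lower number from compound 3 to compound 4 (0.15 log units; within the scatter) and so cannot be told apart from that group here. No measurement at hand explains these steps. Going by these compounds, whether cyclohexyl, phenyl or an amine at this place would keep the number this low remains open.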